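Furoxan benzyl ethers: hemolysis of aminoguanidine and thiosemicarbazone hydrazones

The source may hold more compounds than are shown below. What is called first, only, known or untested is meant among the compounds shown, and "the series" means these compounds.

Measured compounds:
compound 1 `N=C(N)N/N=C/c1ccc(OCc2ccc3no[n+]([O-])c3c2)cc1`, > 200 uM
compound 2 `NC(=S)N/N=C/c1ccc(OCc2ccc3no[n+]([O-])c3c2)cc1`, > 200 uM
compound 3 `N=C(N)N/N=C\c1ccccc1OCc1ccc2no[n+]([O-])c2c1`, 58 uM

In an ADME assay on cells (Erythrocyte, Homo sapiens), read by spectrophotometry and hemolysis, with a stated time of 24 h (a lower number here means a stronger inhibitor, a higher number a weaker inhibitor), compound 1 gives > 200 uM, which is a limit of the assay and not a number. In this assay compound 2 likewise gives > 200 uM, again a limit and not a number. The change between them, (a group of 3 heavy atoms (1 carbon, 1 nitrogen, 1 sulfur; no ring) in place of a group of 3 heavy atoms (1 carbon, 2 nitrogen; no ring), on an amine nitrogen), therefore leaves a step that the two limits leave unreadable from compound 1 to compound 2, because both values sit at the limit of > 200 uM in this assay, at which 2 of the 3 values shown sit. Compound 3 `N=C(N)N/N=C\c1ccccc1OCc1ccc2no[n+]([O-])c2c1` shares its atoms with compound 1 but joins them differently; the difference between the two cores is not broken down here. In this assay, going by the values given here, compound 3 gives 58 uM, the only number among the three.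

Compound 4 `NC(=S)N/N=C\c1ccccc1OCc1ccc2no[n+]([O-])c2c1` has not been measured in this assay. It differs from compound 3 by a group of 3 heavy atoms (1 carbon, 1 nitrogen, 1 sulfur; no ring) in place of a group of 3 heavy atoms (1 carbon, 2 nitrogen; no ring), on an amine nitrogen, the same change as from compound 1 to compound 2, at the same place. Since the measured step of that change is not readable, no direction can be taken from it; the expectation for compound 4 rests on compound 3 and its 58 uM alone.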

Compound 4, concentration for 50% inhibition: 189 uM
For compound 4 the middle estimate is 3.2-fold (0.50 log units) below the measured one; the range from low to high includes it.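

On the core of compound 3, in this assay, putting the group of 3 heavy atoms (1 carbon, 1 nitrogen, 1 sulfur) in place of the group of 3 heavy atoms (1 carbon, 2 nitrogen) on an amine nitrogen gives a 3.3-fold higher number from compound 3 to compound 4 (0.51 log units; beyond the scatter), a modest step. The same change on the core of compound 1 cannot be read, because compound 1 and compound 2 each give a limit of the assay and not a number: the limit of > 200 uM in this assay, at which 2 of the 4 values shown sit. The change is therefore read on one core only, and this single pair shows neither that its direction nor that its size carries from one core to the other.

Open, from the compounds shown here alone, is how the number moves with an oxygen in place of the sulfur, or with a methyl group on the same amine nitrogen. Also open, going by these compounds, is whether any such step can be read on the core of compound 1, where the values shown give no number to compare.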